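The compounds below may be only part of what the source reports. "The series", "measured", "known", "first", "only" and "open" are said of these compounds alone.

The measured compounds in an ADME assay on HepG2 cells (Homo sapiens) for cytotoxicity, read by MTT assay, with a stated time of 48 h (on this read-out lower numbers stand for stronger inhibition and higher numbers for weaker inhibition), are:

compound 1, `O=[N+]([O-])c1ccc(CSc2nnnn2C2CCCCC2)c([N+](=O)[O-])c1`, with 16000 nM;
compound 2, `O=[N+]([O-])c1cc(CSc2nnnn2Cc2ccccc2)cc([N+](=O)[O-])c1`, for which the assay gives only a limit, > 30000 nM;
compound 3, `O=[N+]([O-])c1cc(CSc2nnnn2C2CCCCC2)cc([N+](=O)[O-])c1`, for which the assay again gives only a limit, > 30000 nM.

Compound 3 therefore stands at the limit of the assay, and it is not alone there: the limit of > 30000 nM in this assay, at which 2 of the 3 values shown sit. Only compound 1 gives a number at all, and it is not the same compound pair, so nothing can be read from it about the change in question. Within the data shown here, the one step that shares a place with the present change, a step that the two limits leave unreadable from compound 2 to compound 3, is itself unreadable, since both of its ends sit at the limit.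

Compound 4, `COc1ccc(-n2nnnc2SCc2cc([N+](=O)[O-])cc([N+](=O)[O-])c2)cc1`, is not yet measured. It differs from compound 3 in a single place: 4-methoxyphenyl in place of cyclohexyl on an aromatic nitrogen. Among the measured compounds shown here, no measured step tells how such a swap moves this assay, so the expectation rests only on where compound 3 stands. The most likely outcome is that compound 4 also sits at the limit, and the estimated step of a number no higher from compound 3 to compound 4 (the limit leaves the size open) is expected to lie within the usual scatter. The estimate for compound 4 in this assay is 30000 nM, expected to fall between 12000 nM and 80000 nM.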

Compound 4, half-maximal inhibitory concentration: > 30000 nM
Compound 4 was reported as a limit; the forecaster's own chance of this, stated with the estimate: 60%; the middle value lies on the limit itself.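

In this assay compound 4 gives > 30000 nM, which is a limit and not a number. No step from compound 4 to compound 2 or compound 3 can be read, since each has a limit at both ends: the limit of > 30000 nM in this assay, at which 3 of the 4 values shown sit.

The compounds shown leave open whether benzyl, cyclohexyl and 4-methoxyphenyl on the aromatic nitrogen differ at all in this assay.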